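Thioether side chain variation on the shared core

The source may hold more compounds than are shown below. What is called first, only, known or untested is meant among the compounds shown, and "the series" means these compounds.

Compound 1 `Cc1cc(Nc2cc(-c3ccccc3)[nH]n2)n2nc(SCc3nc4ccccc4[nH]3)nc2n1`: 27800 nM
Compound 2 `Cc1cc(Nc2cc(-c3ccccc3)[nH]n2)n2nc(SCc3ccc(C(F)(F)F)cc3)nc2n1`: 42700 nM
Compound 3 `Cc1cc(Nc2cc(-c3ccccc3)[nH]n2)n2nc(SCC3CC3)nc2n1`: > 50000 nM

In an ADME assay on GES1 cells (Homo sapiens) for inhibition, read by MTT assay, with a stated time of 72 h (a higher number here means a weaker inhibitor, a lower number a stronger inhibitor), compound 1 gives 27800 nM and compound 2 gives 42700 nM. For compound 3 this assay reports only a limit, > 50000 nM, one of the values sitting at the limit of > 50000 nM in this assay, at which 1 of the 3 values shown sits. The steps of a 1.5-fold higher number from compound 1 to compound 2 (0.19 log units; within the scatter), an at least 1.7-fold higher number from compound 1 to compound 3 (0.25 log units; that floor lies within the scatter) and an at least 1.1-fold higher number from compound 2 to compound 3 (0.06 log units; that floor lies within the scatter) all stay within the scatter, so the three compounds cannot be ordered against one another.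

Compound 4 `C#CCSc1nc2nc(C)cc(Nc3cc(-c4ccccc4)[nH]n3)n2n1` differs from compound 3 by ethynyl in place of cyclopropyl on a saturated chain carbon bound to a sulfur. Every measured step exchanges the group on the saturated chain carbon bound to a sulfur without moving the number beyond the scatter, and the nearest, an at least 1.1-fold higher number from compound 2 to compound 3 (0.06 log units; that floor lies within the scatter), gives only a floor. Given that an at least 1.7-fold higher number from compound 1 to compound 3 (0.25 log units; that floor lies within the scatter) and an at least 1.1-fold higher number from compound 2 to compound 3 (0.06 log units; that floor lies within the scatter) stay within the scatter, compound 4 is expected to show the step of a number no higher from compound 3 to compound 4 (the limit leaves the size open). The estimate for compound 4 in this assay is 50000 nM, between 25000 nM and 100000 nM.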

Compound 4, half-maximal inhibitory concentration: 45700 nM
Compound 4: middle estimate off by 1.1-fold (0.04 log units), on the high side; low and high end bracket the measured number.
By their numbers in this assay, from the lowest: compounds 1, 2 and 4 (each within the scatter of the next). At a limit, above all of these: compound 3.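

In this assay, ethynyl in place of 4-(trifluoromethyl)phenyl on a saturated chain carbon bound to a sulfur gives a 1.1-fold higher number from compound 2 to compound 4 (0.03 log units; within the scatter), and ethynyl in place of 1H-benzimidazol-2-yl on a saturated chain carbon bound to a sulfur gives a 1.6-fold higher number from compound 1 to compound 4 (0.22 log units; within the scatter). A group with no ring at this position thus still leaves the number within the scatter of the aromatic groups, so no ring at this position is needed for a number of this size. Ethynyl in place of cyclopropyl on a saturated chain carbon bound to a sulfur gives an at least 1.0-fold lower number from compound 3 to compound 4 (0.03 log units; that floor lies within the scatter), which is only a floor, because compound 3 carries only a limit: the limit of > 50000 nM in this assay, at which 1 of the 4 values shown sits.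

From the compounds shown here alone, whether an amine or a carboxylic acid at this position would move the number beyond the scatter remains open.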